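This account rests on a few compounds, and the source may have more. Where it says the series, first, only, none or still open, it means among the compounds named here.

Compound 1 `O=c1ccoc2cc(OCc3cn(Cc4ccccc4Br)nn3)ccc12` gives > 300000 nM in an ADME assay on L02 cells (Homo sapiens) for cytotoxicity, read by MTT assay, with a stated time of 48 h; on this read-out lower numbers stand for stronger inhibition and higher numbers for weaker inhibition.
Compound 2 `Cc1ccccc1Cn1cc(COc2ccc3c(=O)ccoc3c2)nn1` gives > 300000 nM in this assay.
Compound 3 `O=c1ccoc2cc(OCc3cn(Cc4ccc(Cl)cc4)nn3)ccc12` gives > 300000 nM in this assay.

For compound 1 this value is a limit of the assay, not a number. The same is true of compound 2. It is true of compound 3 as well. Compound 1 therefore stands at a limit in this assay, and the two other values shown are limits too, as the limit of > 300000 nM in this assay, at which 3 of the 3 values shown sit, records. Because of the limit of > 300000 nM in this assay, at which 3 of the 3 values shown sit, the steps a step that the two limits leave unreadable from compound 1 to compound 2 and a step that the two limits leave unreadable from compound 1 to compound 3 cannot be read, and the step that the two limits leave unreadable from compound 2 to compound 3 cannot be read either.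

Compound 4 `COc1ccc(Cn2cc(COc3ccc4c(=O)ccoc4c3)nn2)cc1` differs from compound 1 in one place: 4-methoxyphenyl in place of 2-bromophenyl on a saturated chain carbon bound to an aromatic nitrogen. Going by the values given here, the steps that bear on this change are the ones that alter the same part of the molecule, from compound 1 to compound 2 and from compound 1 to compound 3, and neither has a readable size. In this assay the step from compound 1 to compound 4 is therefore expected to be no more than the scatter, or unreadable again, with compound 4 expected to sit at the same limit as the three measured compounds. The estimated step is a number no higher from compound 1 to compound 4 (the limit leaves the size open). Compound 4 is expected to give 300000 nM, within the range 150000 nM to 1000000 nM.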

Compound 4, half-maximal inhibitory concentration: > 300000 nM
Compound 4: only a limit was reported (the forecaster's own chance of this, stated with the estimate: 85%); the middle value lies on the limit itself.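

In this assay compound 4 gives > 300000 nM, which is a limit of the assay and not a number. No new step can be read between compound 4 and compound 1, compound 2 or compound 3, since all four stand at one limit: the limit of > 300000 nM in this assay, at which 4 of the 4 values shown sit.

The compounds shown leave open whether the groups that differ among them change the read-out in this assay at all.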